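This account rests on a few compounds, and the source may have more. Where it says the series, first, only, none or still open, it means among the compounds named here.

Compound 1 `C#CCOC(c1cccs1)c1cc2ccccc2nc1Cl`: > 100000 nM
Compound 2 `Oc1ccc(-c2cc(COC(c3cccs3)c3cc4ccccc4nc3Cl)on2)cc1`: "not active" (no number reported)

In a functional assay on MCF7 cells (Homo sapiens) for inhibition, read by WST assay, with stated times of 72 h and 2 h (a higher number here means a weaker inhibitor, a lower number a stronger inhibitor), compound 1 gives > 100000 nM, which is a limit of the assay and not a number. Compound 1 therefore stands at the limit of > 100000 nM in this assay, at which 1 of the 2 values shown sits. Compound 2 is reported as "not active" (no number reported), so it offers no number either.

Compound 3 `Fc1ccc(COC(c2cccs2)c2cc3ccccc3nc2Cl)cc1` keeps the core of compound 1 and changes only the end of its side chain: 4-fluorophenyl in place of ethynyl on a saturated chain carbon bound to an oxygen on a saturated carbon. In words, 4-fluorophenyl takes the place of ethynyl on a saturated chain carbon bound to an oxygen on a saturated carbon, which turns propargyl into 4-fluorobenzyl.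

Among the compounds with values here, no measured pair shows what a change of this kind does in this assay, so any expectation here is tentative. With compound 2 also reported as "not active" (no number reported), the expectation stays at the weak end of the scale, with little or no gain in inhibition. The expected change is small, and the estimated step reads an at least 1.4-fold lower number from compound 1 to compound 3 (0.15 log units; that floor lies within the scatter). For compound 3 the estimated value is 70000 nM, with an expected range from 20000 nM to 120000 nM.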

Compound 3, half-maximal inhibitory concentration: 38400 nM
Compound 3: the middle estimate sits 1.8-fold (0.26 log units) above what was measured; low and high end bracket the measured number.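

In this assay, this end of the side chain now yields a first real number, and the change from propargyl to 4-fluorobenzyl gives an at least 2.6-fold lower number from compound 1 to compound 3 (0.41 log units; beyond the scatter). The change therefore does more than leave the compound at the weak end of the scale: on this saturated chain carbon, 4-fluorophenyl in place of ethynyl lowers the number by more than the usual scatter of repeated measurements. The printed size of the step is only a floor, and the real gap may be larger, because compound 1 rests on a limit of the assay and not on a number: the limit of > 100000 nM in this assay, at which 1 of the 3 values shown sits.

This single pair cannot show whether the six-membered aromatic ring alone accounts for the step or whether the fluorine also contributes, and an unsubstituted benzyl or a 4-methoxybenzyl group in the same place would help to separate the two. It also leaves open how far this end of the molecule can be pushed, for instance with a longer chain between the oxygen and the ring or with an amine at its end.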